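The source may hold more compounds than are shown below. What is called first, only, known or untested is meant among the compounds shown, and "the series" means these compounds.

Compound 1 `ClCc1ccc(Cn2cnc3nc(Cl)nc(Cl)c32)cc1` is measured in a functional assay on NCI/ADR-RES cells (Homo sapiens) for cytotoxicity, read by sulforhodamine B assay, with a stated time of 48 h (on this read-out higher numbers stand for weaker inhibition of growth and lower numbers for stronger inhibition of growth), where compound 1 gives 2080 nM. Compound 2 `ClCc1ccccc1Cn1cnc2ncnc(Cl)c21` gives 2080 nM in this assay, and compound 3 `ClCc1ccccc1Cn1cnc2nc(Cl)nc(Cl)c21` gives 2340 nM. Compound 1 and compound 2 stand level at the digits given, and compound 1 and compound 3 lie within the scatter of each other. How the core of compound 1 and the core of compound 3 differ is not broken down here. The change from compound 3 to compound 2 is hydrogen in place of chloro on an aromatic carbon, and it made a 1.1-fold lower number from compound 3 to compound 2 (0.05 log units; within the scatter), a step within the scatter. Compound 4 `ClCc1ccc(Cn2cnc3ncnc(Cl)c32)cc1` has not yet been measured in this assay. Within the data shown here, the change from compound 1 to compound 4 is hydrogen in place of chloro on an aromatic carbon, the same change as the one from compound 3 to compound 2, at a place described in the same words. The expected step is a 1.1-fold lower number from compound 1 to compound 4 (0.04 log units; within the scatter), because a 1.1-fold lower number from compound 3 to compound 2 (0.05 log units; within the scatter) stayed within the scatter and the same change at the same kind of place is expected to behave alike. For compound 4 in this assay the estimate is 1900 nM, with a range from 900 nM to 4000 nM.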

Compound 4, concentration for 50% growth inhibition: 1810 nM
Compound 4: middle estimate off by 1.0-fold (0.02 log units), on the high side, and the stated range covers the measured number.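

In this assay, hydrogen in place of chloro on an aromatic carbon between two ring nitrogen atoms gives a 1.1-fold lower number from compound 1 to compound 4 (0.06 log units; within the scatter), and this step agrees with the one seen on the other core: the same change on two cores in this assay, a 1.1-fold lower number (0.05 log units; within the scatter) from compound 3 to compound 2 and a 1.1-fold lower number (0.06 log units; within the scatter) from compound 1 to compound 4, 1.0-fold (0.01 log units) apart, within the scatter of two such steps The change therefore carries from the core of compound 3 to the core of compound 1 in the limited sense that neither step can be told apart from the scatter, so on these two cores the chloro group at this place can be exchanged for hydrogen with no readable shift in the number. This does not show a transferable effect of any real size, since two steps within the scatter agree without either of them being a measurable change, and two cores set no rule for any other core in the series.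

From the compounds shown here alone, it remains open how an amine or a methoxy group on the same aromatic carbon would behave on either core. All the compounds shown also keep the chloromethyl group, so the effect of replacing it with a plain methyl group or a longer chain is equally open.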